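The compounds below may be only part of what the source reports. "The series", "measured", "known", "first", "only" and "open" are said of these compounds alone.

Measured so far in an ADME assay on the whole organism (Rattus norvegicus, strain Sprague-Dawley) for pharmacokinetics, read by LC-MS, with a stated time of 30 min; on this read-out lower numbers stand for narrower distribution and higher numbers for wider distribution into tissues (two compounds):
compound 1 `N#Cc1ccc(O[C@H]2CN(S(=O)(=O)c3ccc(C(F)(F)F)cc3)C[C@@]2(O)CO)cc1F` gives 180 L/kg
compound 2 `N#Cc1ccc(O[C@H]2CN(S(=O)(=O)c3ccccc3C#N)C[C@@]2(O)CO)cc1F` gives 4.6 L/kg

Of these two, compound 2 holds the lower number (4.6 L/kg) and compound 1 lies far above it, well beyond the usual scatter. Still unmeasured is compound 3 `N#Cc1ccc(O[C@H]2CN(S(=O)(=O)c3ccc(Cl)cn3)C[C@@]2(O)CO)cc1F`, which departs from compound 2 in one place (5-chloropyridin-2-yl in place of 2-cyanophenyl on a sulfonyl sulfur): 5-chloropyridin-2-yl in place of 2-cyanophenyl on a sulfonyl sulfur.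

For the measured compounds named here, only one measured step touches this place, and it was large (a 39-fold lower number from compound 1 to compound 2 (1.59 log units; beyond the scatter)). It shows that a swap of the group on the sulfonyl sulfur has already shifted this assay strongly in this pair. That step brought in the same 2-cyanophenyl group that now leaves. Going by the values given here, the only measured compound without that group is compound 1 (180 L/kg), which points upward. Among the compounds with values here, no measured compound carries 5-chloropyridin-2-yl, however, so the size of the change remains uncertain. A rise smaller than that large step is expected (a 4.3-fold higher number from compound 2 to compound 3 (0.64 log units; beyond the scatter)). The estimate for compound 3 is 20 L/kg (expected range 5 L/kg to 90 L/kg).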

Compound 3, volume of distribution at steady state: 12 L/kg
For compound 3 the middle estimate is 1.7-fold (0.22 log units) above the measured one; the measured number falls inside the stated range.
By their numbers in this assay, from the lowest: compound 2; then compound 3; then compound 1.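

In this assay, putting 5-chloropyridin-2-yl in place of 2-cyanophenyl on the sulfonyl sulfur gives a 2.6-fold higher number from compound 2 to compound 3 (0.42 log units; beyond the scatter) and so only a modest move, while putting it in place of 4-(trifluoromethyl)phenyl gives a 15-fold lower number from compound 1 to compound 3 (1.18 log units; beyond the scatter) and so a large one. Losing 2-cyanophenyl is therefore not enough on its own to restore the very high number of compound 1, and among these three compounds it is compound 1, with its 4-(trifluoromethyl)phenyl group, that stands apart from the other two. No measurement offered here explains why these groups shift the number as they do.

The compounds shown leave open whether the high number of compound 1 follows the trifluoromethyl group or the carbon-only ring that carries it, a question that a plain phenyl group and a pyridine ring bearing trifluoromethyl could help to separate. They also leave open how this read-out would respond if the group on the sulfonyl sulfur carried an amine or a carboxylic acid.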